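Swapping oxolan-3-yl for propyl at a cytotoxicity limit

This account rests on a few compounds, and the source may have more. Where it says the series, first, only, none or still open, it means among the compounds named here.

Compound 1 `COc1ccc([C@H]2CC(=O)N(c3cccc(N(C)C)c3)C2)cc1OC1CCCC1`: > 10000 nM
Compound 2 `COc1ccc([C@H]2CC(=O)N(c3cccc(C)c3)C2)cc1OC1CCCC1`: > 10000 nM
Compound 3 `COc1ccc([C@H]2CC(=O)N(c3cccc(NCC4CCOC4)c3)C2)cc1OC1CCCC1`: > 10000 nM

These compounds were tested in a functional assay on HEK293 cells (Homo sapiens) for cytotoxicity (a lower number here means that less compound is tolerated, a higher number that more compound is tolerated), and none of the results is an exact number. Compound 3 gives > 10000 nM, which is a limit of the assay. It stands with the other two compounds at the limit of > 10000 nM in this assay, at which 3 of the 3 values shown sit.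

Compound 4 `CCCCNc1cccc(N2C[C@@H](c3ccc(OC)c(OC4CCCC4)c3)CC2=O)c1` keeps the core of compound 3 and changes one part of its side chain: propyl in place of oxolan-3-yl on a saturated chain carbon bound to a nitrogen on an aromatic ring. In words, this is propyl in place of oxolan-3-yl on a saturated chain carbon bound to a nitrogen on an aromatic ring.

The closest evidence comes from three swaps of the group on the aromatic ring: a step that the two limits leave unreadable from compound 1 to compound 3, a step that the two limits leave unreadable from compound 2 to compound 3 and a step that the two limits leave unreadable from compound 1 to compound 2. Among the measured compounds shown here, none has a readable size, so they offer only one guide: all three compounds remain at the limit. No shift beyond the usual scatter is therefore expected, and the expected step is a step that the limit leaves unreadable from compound 3 to compound 4. Compound 4 is estimated at 15000 nM, with an expected range from 7000 nM to 40000 nM, and will most likely be reported as a limit too.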

Compound 4, half-maximal cytotoxic concentration: > 10000 nM
Compound 4 gave a limit, no number; the forecaster's own chance of this, stated with the estimate: 85%; the middle value lies beyond the limit too.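

In this assay compound 4 gives > 10000 nM, which is a limit and not a number, so no step linking compound 4 with compound 1, compound 2 or compound 3 can be read: the limit of > 10000 nM in this assay, at which 4 of the 4 values shown sit.

The compounds shown leave open whether their aromatic-ring groups differ in cytotoxicity at all.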